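The source may report more compounds than this note shows. Statements on the series, on what has been measured and on what is new or still open speak of the compounds shown alone.

Measured in an assay on CHO cells for displacement of a labelled ligand from 5-hydroxytryptamine receptor 5A (Homo sapiens); on this read-out higher numbers stand for weaker inhibition and lower numbers for stronger inhibition:
compound 1 `N=C1NC(=O)/C(=C\c2c[nH]c3c(Br)cccc23)N1` gives 112 nM
compound 2 `C/N=C1\NC(=O)/C(=C/c2c[nH]c3c(Br)cccc23)N1` gives 3320 nM
compound 3 `CN1C(=N)NC(=O)/C1=C\c1c[nH]c2c(Br)cccc12` gives 1320 nM

Compound 1 stands lowest of the three numbers. Among the compounds with values here, compound 3 is nearest to it, and the only single-place step measured so far, a 12-fold higher number from compound 1 to compound 3 (1.07 log units; beyond the scatter), arises from methyl in place of hydrogen on an amine nitrogen in a ring. Within the data shown here, compound 2 lies furthest from compound 1, and no single-place step joins the two.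

Compound 4 `N=C1NC(=O)/C(=C\c2c[nH]c3ccccc23)N1` differs from compound 1 in one place: hydrogen in place of bromo on an aromatic carbon. Among the measured compounds shown here, the bromo on the aromatic carbon has not been varied among the measured compounds, so none of the measured steps bears on this change; the one step in hand concerns the ring nitrogen and says nothing about the aromatic carbon. For the measured compounds named here, the expectation in this assay therefore rests on no measured precedent and is held loose. For compound 4 a modest move toward a higher number is expected, a 2.7-fold higher number from compound 1 to compound 4 (0.43 log units; beyond the scatter), with a range wide enough to admit either no change beyond the scatter or a larger loss. Compound 4 is estimated at 300 nM, between 100 nM and 1000 nM.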

Compound 4, inhibition constant: 101 nM
Compound 4: the middle estimate sits 3.0-fold (0.47 log units) above what was measured, and the stated range covers the measured number.
By their numbers in this assay, from the lowest: compounds 4 and 1 (each within the scatter of the next); then compound 3; then compound 2.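

In this assay, hydrogen in place of bromo on an aromatic carbon gives a 1.1-fold lower number from compound 1 to compound 4 (0.04 log units; within the scatter), so at this place the read-out does not separate bromo from hydrogen, and the bromo is not required for a number of this order in the shared core. Within the data shown here, until now the only single-place step concerned the ring nitrogen, a 12-fold higher number from compound 1 to compound 3 (1.07 log units; beyond the scatter), and beside it the new step shows that this series can respond strongly to one change and not at all measurably to another. No measured evidence here accounts for the absence of a shift at this aromatic carbon.

Only bromo and hydrogen are shown at this place, so the effect of chloro, methoxy or a carboxylic acid there remains open. Also open, from the compounds shown here alone, is whether methyl on the ring nitrogen gives a comparable step on the core of compound 4.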